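Butyl-to-pentyl and ethyl-to-propyl steps on a quinoline-isoxazole series

The compounds below may be only part of what the source reports. "The series", "measured", "known", "first", "only" and "open" are said of these compounds alone.

Measured so far:
Compound 1 `CCCCc1cc2ccccc2nc1-c1cc(-c2ccccc2)no1` in a functional assay on COLO 205 cells (Homo sapiens) for inhibition, read by MTT assay, with a stated time of 24 h (a higher number here means a weaker inhibitor, a lower number a stronger inhibitor), gives > 100000 nM, a limit of the assay rather than a number.
Compound 2 `CCCCCc1cc2ccccc2nc1-c1cc(-c2ccccc2)no1` in this assay gives > 100000 nM, again a limit.
Compound 3 `CCc1cc2ccccc2nc1-c1cc(-c2ccc(C(F)(F)F)cc2)no1` in this assay gives > 100000 nM, also a limit.

Three compounds are in hand and none gives a number: all three sit at the limit of > 100000 nM in this assay, at which 3 of the 3 values shown sit. Compound 2 differs from compound 1 by methyl in place of hydrogen on a saturated chain carbon, four bonds along the chain from an aromatic carbon, and the step that the two limits leave unreadable from compound 1 to compound 2 cannot be read because both ends are limits. The difference between the core of compound 1 and the core of compound 3 is not broken down here.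

Compound 4 `CCCc1cc2ccccc2nc1-c1cc(-c2ccc(C(F)(F)F)cc2)no1` is still to be measured in this assay. It differs from compound 3 by methyl in place of hydrogen on a saturated chain carbon, two bonds along the chain from an aromatic carbon. This is the same kind of change as that from compound 1 to compound 2, though not the same: the earlier methyl enters four bonds along the chain from an aromatic carbon, whereas here it enters two bonds along the chain from an aromatic carbon.

Among the compounds with values here, the expectation for compound 4 rests only on compound 3, whose value > 100000 nM is a limit, and on the fact that the one measured step of this kind, a step that the two limits leave unreadable from compound 1 to compound 2, is unreadable and moved nothing out of the limit. The expected step is a step that the limit leaves unreadable from compound 3 to compound 4, most probably again ending at a limit. Compound 4 is therefore estimated at 150000 nM, with the likely range 40000 nM to 600000 nM.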

Compound 4, half-maximal inhibitory concentration: 42200 nM
Compound 4: middle estimate off by 3.6-fold (0.55 log units), on the high side; measured number inside the range.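

On the core of compound 3, methyl in place of hydrogen on a saturated chain carbon, two bonds along the chain from an aromatic carbon, gives an at least 2.3-fold lower number from compound 3 to compound 4 (0.37 log units; beyond the scatter) in this assay, so ethyl to propyl on this core yields a measured number where the shorter chain gives only a limit. The only other step of this kind, on the core of compound 1, enters four bonds along the chain from an aromatic carbon and cannot be read, as both of its ends are limits, so the two steps differ in core as well as in place and neither the carrying of the change from one core to the other nor its failure is shown. The step on the core of compound 3 is also a bound rather than a size, and the series offers little to compare it with: the limit of > 100000 nM in this assay, at which 3 of the 4 values shown sit.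

Open, from the compounds shown here alone, is whether a propyl chain on the core of compound 1 gives a number at all, and whether a butyl or pentyl chain on the core of compound 3 moves the value further from that of compound 4, 42200 nM. Also open, going by these compounds, is what an amine or a carboxylic acid in place of the chain would do in this assay.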